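Chain-end extension on compound 3 in the aminochlorobenzamide series

The source may report more compounds than this note shows. Statements on the series, on what has been measured and on what is new or still open speak of the compounds shown alone.

Compound 3 `COc1cc(N)c(Cl)cc1C(=O)NC1CCN(CCCCCO)CC1` stands only at a limit: in a functional assay on HEK293 cells for activation of 5-hydroxytryptamine receptor 4 (Homo sapiens), read by cAMP accumulation (on this read-out higher numbers stand for larger maximal responses and lower numbers for smaller maximal responses), compound 3 gives > 100%, a limit of the assay rather than a number. The parent compound 1 `COc1cc(N)c(Cl)cc1C(=O)NC1CCNCC1` likewise reports a limit, as compound 1 gives > 100% in this assay. Compound 2 `CCN1CCC(NC(=O)c2cc(Cl)c(N)cc2OC)CC1` also reaches a limit, since compound 2 gives > 100% in this assay. The measured steps therefore remain unreadable: a step that the two limits leave unreadable from compound 1 to compound 2, a step that the two limits leave unreadable from compound 1 to compound 3 and a step that the two limits leave unreadable from compound 2 to compound 3, all because of the limit of > 100% in this assay, at which 3 of the 3 values shown sit.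

Compound 4 `COc1cc(N)c(Cl)cc1C(=O)NC1CCN(CCCCCN2C(=O)c3ccccc3C2=O)CC1` differs from compound 3 by a group of 11 heavy atoms (8 carbon, 1 nitrogen, 2 oxygen; one five-membered non-aromatic ring with 1 hetero atom, one six-membered aromatic ring of carbon only) in place of one oxygen atom, on a saturated chain carbon, five bonds along the chain from an amine nitrogen in a ring. Among the compounds with values here, none of the measured steps bears readably on this change, and the only evidence is that every compound with this core so far reaches the limit (the limit of > 100% in this assay, at which 3 of the 3 values shown sit). Compound 4 is therefore expected to give a full maximal response again, with no step beyond the scatter from compound 3 to compound 4 in this assay, estimated as a number no higher from compound 3 to compound 4 (the limit leaves the size open). Compound 4 is estimated at 100%, within 80% to 115%.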

Compound 4, intrinsic activity: the largest response reached, in percent of the reference agonist's: > 100%
Compound 4: only a limit was reported; the forecaster's own chance of this, stated with the estimate: 50%; the middle value lies on the limit itself.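

Compound 4 gives > 100% in this assay and this is a limit of the assay, not a number. Within the data shown here, no step from compound 3 to compound 4 can be read because the values stop at the limit: the limit of > 100% in this assay, at which 4 of the 4 values shown sit. Going by these compounds, the true size of the maximal responses of compound 3 and compound 4 stays open.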